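The source may report more compounds than this note shows. Statements on the series, on what has been measured and on what is new or still open speak of the compounds shown alone.

Compound 1 `CNC(=O)c1cc(Oc2ccc(C(=O)/C=C/c3ccc(F)cc3Cl)cc2)ccn1` was examined in a functional assay on PC-3 cells (Homo sapiens) for cytotoxicity, read by MTT assay, with a stated time of 72 h; on this read-out higher numbers stand for weaker inhibition and lower numbers for stronger inhibition. In this assay compound 1 gives 4760 nM. Compound 2 `CNC(=O)c1cc(Oc2ccc(C(=O)/C=C/c3cc(OC)c(OC)c(OC)c3)cc2)ccn1` was run in this assay, and compound 2 gives 3150 nM. Compound 3 `CNC(=O)c1cc(Oc2ccc(/C=C/C(=O)c3ccc(Cl)cc3)cc2)ccn1` carries no number in this assay: for compound 3 the entry reads "not determined" (no result reported), so no result is available for it. Of the two numbers at hand, compound 1 holds the higher one, and its nearest neighbour is compound 2, whose number lies within the usual scatter of repeated measurements, so the two compounds cannot be ordered on these numbers.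

Compound 4 `CNC(=O)c1cc(Oc2ccc(C(=O)/C=C/c3ccccc3)cc2)ccn1` differs from compound 1 in a single place: phenyl in place of 2-chloro-4-fluorophenyl on a double-bonded chain carbon bound to a double-bonded chain carbon. Among the measured compounds shown here, no pair of measured compounds spans this change, so nothing beyond the two numbers for compound 1 and compound 2 can guide the expectation. Both of those numbers sit close together, and the change removes only the halogens of the ring on the chain. The step of a 1.5-fold higher number from compound 1 to compound 4 (0.17 log units; within the scatter) is therefore expected to be modest, leaning toward a weaker result, but quite possibly staying within the scatter. On that basis compound 4 is expected to give about 7000 nM in this assay, with an estimated range from 2800 nM to 18000 nM.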

Compound 4, half-maximal inhibitory concentration: 3170 nM
Beside the measured number, compound 4's estimate is 2.2-fold (0.34 log units) above it; measured number inside the range.
By their numbers in this assay, from the lowest: compounds 2, 4 and 1 (each within the scatter of the next).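

The replacement of 2-chloro-4-fluorophenyl by phenyl on a double-bonded chain carbon bound to a double-bonded chain carbon gives the first single-place comparison among these compounds, and in this assay it reads as a 1.5-fold lower number from compound 1 to compound 4 (0.18 log units; within the scatter). At this position, then, the ring can lose both its chlorine and its fluorine without the number leaving the usual scatter, although this rests on one pair of compounds in one cell line. No information is available that would account for this result.

Going by these compounds, this step covers the chlorine and the fluorine only as a pair, so the contribution of each halogen alone remains unknown, as does the outcome of a larger change on the same ring, such as an amine or a carboxylic acid in their place. The compounds shown also leave open whether any group at this position can move the number beyond the scatter at all, and how a methoxy group alone would compare with the three on the ring of compound 2.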